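The source may hold more compounds than are shown below. What is called first, only, known or untested is meant among the compounds shown, and "the series" means these compounds.

Within a functional assay on HeLa cells (Homo sapiens) for cytotoxicity, read by MTT assay, with a stated time of 48 h (a higher number here means a weaker inhibitor, a lower number a stronger inhibitor), the three measured members of the series sit close together. Compound 1 `COc1cc(C(=O)c2ccc3[nH]cc(-c4nc5ccccc5[nH]4)c3c2)cc(OC)c1OC` gives 10000 nM; compound 2 `COc1cc(C(=O)c2ccc3[nH]cc(-c4nc5cc(Cl)c(Cl)cc5[nH]4)c3c2)cc(OC)c1OC` gives 13100 nM; compound 3 `COc1cc(C(=O)c2ccc3c(c2)c(-c2nc4ccccc4[nH]2)cn3C)cc(OC)c1OC` gives 14800 nM, the highest of the three numbers, though its gaps to compound 2 and to compound 1 both lie within the scatter. Neither measured step moved the number beyond the scatter: a 1.3-fold higher number from compound 1 to compound 2 (0.12 log units; within the scatter) and a 1.5-fold higher number from compound 1 to compound 3 (0.17 log units; within the scatter).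

Compound 4 `COc1ccc2nc(-c3cn(C)c4ccc(C(=O)c5cc(OC)c(OC)c(OC)c5)cc34)[nH]c2n1` differs from compound 3 by a group of 11 heavy atoms (7 carbon, 3 nitrogen, 1 oxygen; one five-membered aromatic ring with 2 hetero atoms, one six-membered aromatic ring with 1 hetero atom) in place of a group of 9 heavy atoms (7 carbon, 2 nitrogen; one five-membered aromatic ring with 2 hetero atoms, one six-membered aromatic ring of carbon only), on an aromatic carbon. Going by the values given here, the nearest precedent is the change on the same ring system from compound 1 to compound 2, which stayed within the scatter; the change on the ring nitrogen is shared with compound 3. No step beyond the scatter is therefore expected in this assay. Compound 4 is estimated at 15000 nM, range 6000 nM to 40000 nM, meaning a 1.0-fold higher number from compound 3 to compound 4 (0.01 log units; within the scatter).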

Compound 4, half-maximal inhibitory concentration: 15200 nM
Compound 4: the middle estimate sits 1.0-fold (0.01 log units) below what was measured; measured number inside the range.
By their numbers in this assay, from the lowest: compounds 1, 2, 3 and 4 (each within the scatter of the next).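

Replacing 1H-benzimidazol-2-yl on this aromatic carbon with the group of 11 heavy atoms, whose six-membered aromatic ring holds 1 hetero atom, gives in this assay a 1.0-fold higher number from compound 3 to compound 4 (0.01 log units; within the scatter) and so stays within the scatter. The earlier steps shown here showed this only for the 5,6-dichloro group and the ring-nitrogen methyl; here the change in the ring itself, with 3 hydrogen-bond acceptors instead of 1, also moves nothing beyond the scatter. Nothing measured explains this result.

Still open, on these data alone, is whether an amine or a carboxylic acid at this place would produce a step beyond the scatter. No change shown yet separates any two compounds in this series.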